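The compounds below may be only part of what the source reports. "The series", "measured", "known", "first", "only" and "open" are said of these compounds alone.

Measured so far in a functional assay on KB cells (Homo sapiens) for antiproliferative activity, read by sulforhodamine B assay, with a stated time of 3 days; a higher number here means that more compound is needed for the effect, a lower number that less compound is needed:
compound 1, `CCC1=C(O)c2c(oc(-c3ccc(CC)cc3)cc2=O)C(CC)(CC)C1=O`: 21.9 uM
compound 2, `CCCc1ccc(-c2cc(=O)c3c(o2)C(CC)(CC)C(=O)C(CC)=C3O)cc1`: a limit, > 53 uM
compound 3, `CCC1=C(O)c2c(oc(-c3ccc(OC(F)(F)F)cc3)cc2=O)C(CC)(CC)C1=O`: 36.5 uM

Compound 1 holds the lowest of the two numbers recorded; compound 3 sits within the scatter of it, a 1.7-fold higher number from compound 1 to compound 3 (0.22 log units; within the scatter). Compound 2 reaches only the limit, (the limit of > 53 uM in this assay, at which 1 of the 3 values shown sits), giving an at least 2.4-fold higher number from compound 1 to compound 2 (0.38 log units; beyond the scatter).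

Compound 4, `CCC1=C(O)c2c(oc(-c3ccc(Br)cc3)cc2=O)C(CC)(CC)C1=O`, changes the same position: bromo in place of ethyl on an aromatic carbon. The two steps from compound 1 that bear on this position run in the same direction, one within the scatter and one at least modest. Bromo is a new entry and neither step reproduces it, so the expected step is a 1.2-fold higher number from compound 1 to compound 4 (0.07 log units; within the scatter), small and within the scatter. Compound 4 is estimated at 26 uM, between 12 uM and 55 uM.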

Compound 4, concentration for half-maximal effect: > 48.1 uM
Compound 4: only a limit was reported; the forecaster's own chance of this, stated with the estimate: 15%; middle value at least 1.8-fold (0.26 log units) from the limit.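

Compound 4 reaches only a limit in this assay: the limit of > 48.1 uM in this assay, at which 1 of the 4 values shown sits.
Bromo in place of ethyl gives an at least 2.1-fold higher number from compound 1 to compound 4 (0.34 log units; beyond the scatter), so the move away from compound 1 at this position is no longer seen only with the longer propyl chain of compound 2, while trifluoromethoxy in compound 3 remains within the scatter of compound 1.
Against trifluoromethoxy the result is an at least 1.3-fold higher number from compound 3 to compound 4 (0.11 log units; that floor lies within the scatter), which sets no order between these two, and the step between compound 2 and compound 4 cannot be read, since both are limits.

On these data alone, whether any group on this aromatic carbon, such as an amine or a carboxylic acid, gives a lower number than the ethyl of compound 1 stays open.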